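Fluorine on the benzoyl ring and cytotoxicity of pyrimidinone thioethers

The compounds below may be only part of what the source reports. "The series", "measured", "known", "first", "only" and "open" are said of these compounds alone.

Compound 1 `CC(C)c1c(Cc2c(Cl)cccc2Cl)nc(SCC(=O)c2ccccc2)[nH]c1=O`: in an ADME assay on MT4 cells (Homo sapiens) for cytotoxicity, read by MTT assay (on this read-out higher numbers stand for lower toxicity in this test and lower numbers for higher toxicity in this test), compound 1 gives > 56000 nM, which is a limit of the assay and not a number.
Compound 2 `CC(C)c1c(Cc2c(Cl)cccc2Cl)nc(SCC(=O)c2ccc(F)cc2)[nH]c1=O`: in this assay compound 2 gives > 54000 nM, again a limit of the assay.
Compound 3 `Cc1c(Cc2c(F)cccc2Cl)nc(SCC(=O)c2ccccc2)[nH]c1=O`: in this assay compound 3 gives > 12000 nM, also a limit of the assay.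

The change from compound 1 to compound 2 is fluoro in place of hydrogen on an aromatic carbon. Both values are limits, so a step that the two limits leave unreadable from compound 1 to compound 2; the reading is bounded by the limit of > 56000 nM in this assay, at which 1 of the 3 values shown sits, and (the limit of > 54000 nM in this assay, at which 1 of the 3 values shown sits). The difference between the cores of compound 1 and compound 3 is not broken down here. Compound 3 itself sits at the limit of > 12000 nM in this assay, at which 1 of the 3 values shown sits. The unmeasured compound 4 `Cc1c(Cc2c(F)cccc2Cl)nc(SCC(=O)c2ccc(F)cc2)[nH]c1=O` carries the same change relative to compound 3, namely (fluoro in place of hydrogen on an aromatic carbon), at a place described in the same words as for the earlier pair.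

Since the earlier step could not be sized, the expectation for compound 4 rests on the limits themselves. Compound 4 is expected to show a limit as well, estimated around 30000 nM with a plausible range from 12000 nM to 100000 nM. The expected step is a step that the limit leaves unreadable from compound 3 to compound 4.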

Compound 4, half-maximal cytotoxic concentration: > 59000 nM
Compound 4 gave a limit, no number; the forecaster's own chance of this, stated with the estimate: 85%; middle value at least 1.9-fold (0.29 log units) away from the limit.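

Compound 3 and compound 4 both give limits in this assay and not numbers, so the step between them cannot be read, and the same holds for compound 1 and compound 2. Going by these compounds, whether fluoro in place of hydrogen on an aromatic carbon shifts the half-maximal cytotoxic concentration at all, in either pair, stays open: all four values shown are limits.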